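Removing the bromo from a hydroxyphenyl amide: an inactive series

The source may report more compounds than this note shows. Statements on the series, on what has been measured and on what is new or still open speak of the compounds shown alone.

Measured so far in an assay for inhibition of HSP60/HSP10 (Homo sapiens), with a stated time of 60 min; a lower number here means a stronger inhibitor, a higher number a weaker inhibitor:
Compound 1, `O=C(Nc1ccc(Sc2nc3ccccc3s2)c(Cl)c1)c1cccc(Br)c1`: compound 1 gives > 100000 nM, a limit of the assay.
Compound 2, `COc1c(Br)cccc1C(=O)Nc1ccc(Sc2nc3ccccc3s2)c(Cl)c1`: compound 2 gives > 100000 nM, a limit of the assay.
Compound 3, `O=C(Nc1ccc(Sc2nc3ccccc3s2)c(Cl)c1)c1cc(Br)ccc1O`: compound 3 gives > 100000 nM, a limit of the assay.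

Compound 3 stands at the limit, as do both others; this is the situation described by the limit of > 100000 nM in this assay, at which 3 of the 3 values shown sit. The three steps among them, a step that the two limits leave unreadable from compound 1 to compound 2, a step that the two limits leave unreadable from compound 1 to compound 3 and a step that the two limits leave unreadable from compound 2 to compound 3, therefore cannot be sized.

Compound 4 is `O=C(Nc1ccc(Sc2nc3ccccc3s2)c(Cl)c1)c1ccccc1O`. It differs from compound 3 by hydrogen in place of bromo on an aromatic carbon. Among the measured compounds shown here, no measured step removes a bromo, so none bears directly on this change, and no step in the set was readable at all. Everything seen so far sits at the limit, and there is no sign that a smaller change than those already tried would move off it.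

Compound 4 is expected to give 150000 nM, with a range of 30000 nM to 1000000 nM. The expected step is a step that the limit leaves unreadable from compound 3 to compound 4, most likely again only a limit.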

Compound 4, half-maximal inhibitory concentration: > 100000 nM
Compound 4: a limit, no number; the forecaster's own chance of this, stated with the estimate: 85%; the middle value is on the limit's open side.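

Compound 4 gives > 100000 nM in this assay, again a limit of the assay. Its steps from compound 1, compound 2 and compound 3 therefore cannot be read: the limit of > 100000 nM in this assay, at which 4 of the 4 values shown sit. The compounds shown leave open how weak each one truly is, and whether any change to them would give a readable value.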